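Moving a Hydroxyl Group on a Topoisomerase Inhibitor Core

This account rests on a few compounds, and the source may have more. Where it says the series, first, only, none or still open, it means among the compounds named here.

Compound 1 `Oc1cccc(-c2cc(-c3ccsc3)cc(-c3ccccc3O)n2)c1` and compound 2 `Oc1ccc(-c2cc(-c3ccsc3)cc(-c3ccccc3O)n2)cc1` share one core. In an assay on isolated protein for inhibition of DNA topoisomerase 1 (Homo sapiens), with a stated time of 30 min, tested at 100 uM (on this read-out lower numbers stand for a weaker effect and higher numbers for a stronger effect at the one concentration tested), compound 1 gives 10.2%, and compound 2 gives 13.8%. The change 4-hydroxyphenyl in place of 3-hydroxyphenyl on an aromatic carbon made a step of a number 3.6 percentage points higher from compound 1 to compound 2 (within the scatter). Compound 3 `Oc1ccc(-c2cc(-c3ccco3)cc(-c3cccc(O)c3)n2)cc1` has another core, and its difference from compound 1 is not broken down here. In this assay compound 3 gives 100%. Compound 4 `Oc1ccc(-c2cc(-c3ccco3)cc(-c3ccc(O)cc3)n2)cc1` is not yet measured and carries the same kind of change, (4-hydroxyphenyl in place of 3-hydroxyphenyl on an aromatic carbon); around the place the surroundings differ, since in compound 4 the group is meta to a 4-hydroxyphenyl group and meta to a furan-2-yl group. The expected step of a number 8 percentage points lower from compound 3 to compound 4 (within the scatter) is small because the same kind of change earlier gave only a number 3.6 percentage points higher from compound 1 to compound 2 (within the scatter). In this assay compound 4 is therefore estimated at 92%, between 70% and 100%.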

Compound 4, a percentage reported as inhibition, at one concentration (the size of the read-out at that concentration, not a potency): 100%
Beside the measured number, compound 4's estimate is 8 percentage points below it; low and high end bracket the measured number.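

In this assay, 4-hydroxyphenyl in place of 3-hydroxyphenyl gives no change at the digits printed from compound 3 to compound 4 (within the scatter), and this step agrees with the earlier one on the other core: the same change on two cores in this assay, a number 3.6 percentage points higher (within the scatter) from compound 1 to compound 2 and no change at the digits printed (within the scatter) from compound 3 to compound 4, 3.6 percentage points apart, within the scatter of two such steps. Across these two cores, then, the change leaves the read-out about where it was. Still, compound 3 gives 100% and compound 4 gives 100%, the top of a read-out taken at a single concentration, so this pair does not show that the two groups match in potency, and two cores cannot speak for the whole series.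

The compounds shown leave open how the step would look with an amine or a carboxylic acid in place of the hydroxyl. They also leave open how compound 3 and compound 4 would compare at lower concentrations.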